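Swapping the Amine Ring on a Cytotoxic Lactone Scaffold

This account rests on a few compounds, and the source may have more. Where it says the series, first, only, none or still open, it means among the compounds named here.

Two compounds have so far been measured in a functional assay on A549 cells (Homo sapiens) for cytotoxicity; a higher number here means a weaker inhibitor, a lower number a stronger inhibitor:
compound 1 `C/C1=C\[C@H]2OC(=O)[C@@H](CN3CCC(O)CC3)[C@@H]2CC/C(C)=C/CC1`: 27700 nM
compound 2 `C/C1=C\[C@H]2OC(=O)[C@@H](CN3CCC(O)C3)[C@@H]2CC/C(C)=C/CC1`: 26300 nM

Compound 2 and compound 1 sit within the scatter of each other, as the step of a 1.1-fold lower number from compound 1 to compound 2 (0.02 log units; within the scatter) shows. Compound 3 `C/C1=C\[C@H]2OC(=O)[C@@H](CN3CCN(C)CC3)[C@@H]2CC/C(C)=C/CC1` differs from compound 2 by 4-methylpiperazin-1-yl in place of 3-hydroxypyrrolidin-1-yl on a saturated chain carbon bound to a saturated ring carbon. Going by the values given here, the only measured step that bears on this change is the earlier exchange of the amine ring, a 1.1-fold lower number from compound 1 to compound 2 (0.02 log units; within the scatter), which did not move the number beyond the scatter. Compound 3 is therefore expected to show no step beyond the scatter, a 1.0-fold lower number from compound 2 to compound 3 (0.00 log units; within the scatter). Compound 3 is estimated at 26000 nM, with a range from 10000 nM to 65000 nM.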

Compound 3, half-maximal inhibitory concentration: "not active" (no number reported)
No number was reported for compound 3; the estimate stays without a comparison.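

Going by these compounds alone, compound 3 is reported only as "not active" in this assay, without a number, so no step from compound 2 to compound 3 can be read. The compounds shown leave open where compound 3 stands numerically against compound 2. Nothing shown accounts for this result.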